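The source may hold more compounds than are shown below. What is called first, only, known or untested is meant among the compounds shown, and "the series" means these compounds.

The measured compounds:
compound 1, `COc1cc2c(Oc3ccc(NC(=O)Nc4ccc(OC(F)(F)F)cc4)cc3)ccnc2cc1OCCCCCCC(=O)NO`, giving 3200 nM in a functional assay on MCF7 cells (Homo sapiens) for antiproliferative activity, read by MTT assay; a higher number here means a weaker inhibitor, a lower number a stronger inhibitor
compound 2, `COc1cc2c(Oc3ccc(NC(=O)Nc4ccc(C(F)(F)F)cc4Cl)cc3)ccnc2cc1OCCCCCCC(=O)NO`, giving 500 nM

Among the measured compounds shown here, compound 2 stands lowest of the two numbers; the only other is compound 1, which lies above it by a 6.4-fold lower number from compound 1 to compound 2 (0.81 log units; beyond the scatter). Compound 3, `COc1cc2c(Oc3ccc(NC(=O)N/N=C/c4ccccc4)cc3)ccnc2cc1OCCCCCCC(=O)NO`, is built from compound 2 by the change (a group of 8 heavy atoms (7 carbon, 1 nitrogen; one six-membered aromatic ring of carbon only) in place of a group of 11 heavy atoms (7 carbon, 3 fluorine, 1 chlorine; one six-membered aromatic ring of carbon only), on an amide-type nitrogen). For the measured compounds named here, the single measured step bears on this only loosely: it exchanged one substituted ring for another on the same nitrogen and shifted the number by a 6.4-fold lower number from compound 1 to compound 2 (0.81 log units; beyond the scatter), showing that this part of the molecule matters. Going by the values given here, the group entering in compound 3 is smaller and carries a double bond outside aromatic rings in place of fluorine and chlorine, a kind of change no measured pair covers. A weaker inhibitor than compound 2 therefore seems likely, with wide uncertainty. Compound 3 is expected at 2000 nM, between 600 nM and 7000 nM. That corresponds to an expected step of a 4.0-fold higher number from compound 2 to compound 3 (0.60 log units; beyond the scatter).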

Compound 3, half-maximal inhibitory concentration: 610 nM
For compound 3 the middle estimate is 3.3-fold (0.52 log units) above the measured one, and the stated range covers the measured number.
By their numbers in this assay, from the lowest: compounds 2 and 3 (each within the scatter of the next); then compound 1.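

At this position on the amide-type nitrogen, the 2-chloro-4-(trifluoromethyl)phenyl group can be replaced by a group with a double bond outside aromatic rings and no fluorine or chlorine, and the number in this assay stays within the usual scatter (a 1.2-fold higher number from compound 2 to compound 3 (0.09 log units; within the scatter)). Fluorine and chlorine are therefore not needed in this group for a number of this size, and compound 3 also lies beyond the scatter from compound 1 (a 5.2-fold lower number from compound 1 to compound 3 (0.72 log units; beyond the scatter)). No measurement shown here explains why these two groups give such similar numbers, or what separates them from the 4-(trifluoromethoxy)phenyl group of compound 1.

The compounds shown leave open whether a pyridine ring or a 4-methoxyphenyl ring could take the place of the end phenyl ring of compound 3 with a similar result. They also leave open how a shorter chain carrying the same hydroxamic acid would behave with this new group.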